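The compounds below may be only part of what the source reports. "The series", "measured", "known", "first", "only" and "open" are said of these compounds alone.

Measured so far in an ADME assay on H9c2 cells (Rattus norvegicus) for cytotoxicity, read by MTT assay; on this read-out higher numbers stand for weaker inhibition and lower numbers for stronger inhibition:
compound 1 `O=CC1=C(Cl)c2cc(Cl)ccc2SC1`: > 100 ug/mL
compound 2 `O=CC1=C(Cl)c2cc(Br)ccc2SC1`: > 100 ug/mL

Compound 1 stands at > 100 ug/mL, which is a limit and not a number. Compound 2 gives > 100 ug/mL, also a limit. For the measured compounds named here, the series so far therefore rests on (the limit of > 100 ug/mL in this assay, at which 2 of the 2 values shown sit).

Compound 3 `CCN(CC)CC1=C(Cl)c2cc(Cl)ccc2SC1` carries (diethylamino)methyl in place of formyl on a double-bonded ring carbon.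

Going by the values given here, the only measured step, a step that the two limits leave unreadable from compound 1 to compound 2, is bromo in place of chloro on an aromatic carbon. It has no readable size and does not involve the double-bonded ring carbon, so it gives no size to carry over. In this assay, only a modest move toward stronger inhibition is expected, and another limit reading remains likely. The expected change is an at least 1.1-fold lower number from compound 1 to compound 3 (0.04 log units; that floor lies within the scatter).

For compound 3 the estimated value is 90 ug/mL, with an expected range of 30 ug/mL to 200 ug/mL.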

Compound 3, half-maximal inhibitory concentration: > 100 ug/mL
Compound 3 ended at the assay's limit; the forecaster's own chance of this, stated with the estimate: 55%; at least 1.1-fold (0.04 log units) between middle value and limit.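

In this assay compound 3 gives > 100 ug/mL, a limit and not a number. For the compounds shown here, compound 1 also sits at a limit, so no step from compound 1 to compound 3 can be read. Whether any change on the shared core moves the number stays open, with the whole series at one value: the limit of > 100 ug/mL in this assay, at which 3 of the 3 values shown sit.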